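Iodo for Isopropyl on a Sulfonate Ester Urea

The compounds below may be only part of what the source reports. "The series", "measured", "known", "first", "only" and "open" are said of these compounds alone.

Measured compounds:
compound 1, `CCCCCNC(=O)Nc1ccc(S(=O)(=O)Oc2ccccc2C(C)C)cc1`, giving 4700 nM in a functional assay on HT-1080 cells (Homo sapiens) for antiproliferative activity, read by sulforhodamine B assay, with a stated time of 48 h; on this read-out lower numbers stand for stronger inhibition and higher numbers for weaker inhibition
compound 2, `CCCCCNC(=O)Nc1ccc(S(=O)(=O)Oc2ccccc2I)cc1`, giving 6900 nM
compound 3, `CC(C)c1ccccc1OS(=O)(=O)c1ccc(NC(=O)NCCCCl)cc1`, giving 2700 nM

Compound 3 differs from compound 2 by a step beyond the scatter, while its gap to compound 1 lies within the scatter. From compound 1 to compound 2 the change is iodo in place of isopropyl on an aromatic carbon, and it made a 1.5-fold higher number from compound 1 to compound 2 (0.17 log units; within the scatter). The same change, (iodo in place of isopropyl on an aromatic carbon), turns compound 3 into compound 4, `O=C(NCCCCl)Nc1ccc(S(=O)(=O)Oc2ccccc2I)cc1`, not yet measured in this assay. The two cores differ by chloro in place of ethyl on a saturated chain carbon, three bonds along the chain from an amide-type nitrogen, which made a 1.7-fold lower number from compound 1 to compound 3 (0.24 log units; within the scatter). Because a 1.5-fold higher number from compound 1 to compound 2 (0.17 log units; within the scatter) was small, compound 4 is expected to show a step of similar size, a 1.5-fold higher number from compound 3 to compound 4 (0.17 log units; within the scatter). Compound 4 is therefore estimated at 4000 nM, with a likely range from 2000 nM to 8000 nM.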

Compound 4, half-maximal inhibitory concentration: 2800 nM
Estimate against measurement, compound 4: 1.4-fold (0.15 log units) above; the range from low to high includes it.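

In this assay, putting iodo in place of isopropyl gave a 1.0-fold higher number from compound 3 to compound 4 (0.02 log units; within the scatter), so this change stayed small on the second core, as it had on the first: the same change on two cores in this assay, a 1.5-fold higher number (0.17 log units; within the scatter) from compound 1 to compound 2 and a 1.0-fold higher number (0.02 log units; within the scatter) from compound 3 to compound 4, 1.4-fold (0.15 log units) apart, within the scatter of two such steps. The chloro change gave a 2.5-fold lower number from compound 2 to compound 4 (0.39 log units; beyond the scatter), and although this step lies beyond the scatter and the earlier one within it, the two agree: the same change on two cores in this assay, a 1.7-fold lower number (0.24 log units; within the scatter) from compound 1 to compound 3 and a 2.5-fold lower number (0.39 log units; beyond the scatter) from compound 2 to compound 4, 1.4-fold (0.15 log units) apart, within the scatter of two such steps. Each change therefore carried over between these two cores, but two cores cannot show that it would hold on others, and these numbers do not explain why it held here.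

Still open, as far as these compounds go, is how a methoxy group or a nitrile in place of iodo would behave. From the compounds shown here alone, whether an amine or a longer chain in place of the chloro would follow the same pattern is also open.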